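Chloro for Bromo: Expected Potency of Compound 3

The source may report more compounds than this note shows. Statements on the series, on what has been measured and on what is new or still open speak of the compounds shown alone.

Compound 1 `COc1cc(C(=O)c2sc(-c3ccc(Br)cc3)cc2N)cc(OC)c1OC`: 100 nM
Compound 2 `COc1cc(C(=O)c2sc(-c3ccc([N+](=O)[O-])cc3)cc2N)cc(OC)c1OC`: 100 nM

In a functional assay on L1210 cells (Mus musculus) for antiproliferative activity (a lower number here means a stronger inhibitor, a higher number a weaker inhibitor), compound 1 gives 100 nM, and compound 2 gives 100 nM. On these numbers compound 1 stands level with compound 2. Compound 3 `COc1cc(C(=O)c2sc(-c3ccc(Cl)cc3)cc2N)cc(OC)c1OC` differs from compound 1 by chloro in place of bromo on an aromatic carbon. For the measured compounds named here, the one measured step that bears on this, no change at the digits printed from compound 1 to compound 2 (within the scatter), also exchanged the bromo on an aromatic carbon, and it left the value unchanged within the scatter. A step beyond the scatter is therefore not expected here. Compound 3 is expected to give 100 nM, in a range from 50 nM to 200 nM, which means an expected step of no change at the digits printed from compound 1 to compound 3 (within the scatter).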

Compound 3, half-maximal inhibitory concentration: 93 nM
Compound 3: middle estimate off by 1.1-fold (0.03 log units), on the high side; the range from low to high includes it.
By their numbers in this assay, from the lowest: compounds 3, 1 and 2 (each within the scatter of the next).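

In this assay chloro in place of bromo reads as a 1.1-fold lower number from compound 1 to compound 3 (0.03 log units; within the scatter) and chloro in place of nitro as a 1.1-fold lower number from compound 2 to compound 3 (0.03 log units; within the scatter) here. This place on the six-membered aromatic ring now carries bromo, nitro or chloro with all three compounds within the scatter of one another, so a second exchange of the bromo also leaves the value in place. Nothing measured explains this sameness. Going by these compounds, whether it extends to an amine or a carboxylic acid at this place stays open, as does whether a longer chain there is accepted equally well.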